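A few compounds are considered here, and "the series" means these few. Any claim that something is new, unique, unknown or untested is made for them only; others in the source may bear on it.

Going by the values given here, compound 2 `COc1cc(Cl)cc(-c2nn(-c3cccc(NC(=O)Nc4ccc(Cl)c(C(F)(F)F)c4)c3)cc2-c2ccncc2)c1` gives the lower of the two numbers so far in a functional assay on RPMI-8226 cells (Homo sapiens) for inhibition, read by sulforhodamine B assay, with a stated time of 48 h, tested at 10 uM (a lower number here means a stronger effect, a higher number a weaker effect of the compound at the concentration tested), at -29.1%. Among the compounds with values here, compound 1 `O=C(Nc1cccc(-n2cc(-c3ccncc3)c(-c3cc(O)cc(Cl)c3)n2)c1)Nc1ccc(Cl)c(C(F)(F)F)c1` gives 13.8% in this assay, and the single measured step, a number 42.9 percentage points lower from compound 1 to compound 2 (beyond the scatter), concerns the oxygen on the aromatic ring and not the anilide end of the urea. Compound 3 `COc1cc(Cl)cc(-c2nn(-c3cccc(NC(=O)Nc4cccc(C(F)(F)F)c4)c3)cc2-c2ccncc2)c1` differs from compound 2 by hydrogen in place of chloro on an aromatic carbon. Within the data shown here, no measured step touches this change, so the expectation for compound 3 is a step of about a number 7.1 percentage points higher from compound 2 to compound 3 (within the scatter), within the scatter, in either direction. The expected value for compound 3 in this assay is -22%, estimated to lie between -60% and 15%.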

Compound 3, a percentage reported as activity, at one concentration (the size of the read-out at that concentration, not a potency): -14.2%
Estimate against measurement, compound 3: 7.8 percentage points below; low and high end bracket the measured number.
By their numbers in this assay, from the lowest: compound 2; then compound 3; then compound 1.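

In this assay, the change from 4-chloro-3-(trifluoromethyl)phenyl to 3-(trifluoromethyl)phenyl gives a number 14.9 percentage points higher from compound 2 to compound 3 (beyond the scatter) and so shows that the anilide end of the urea, untouched by the earlier step, also moves this read-out. In this one pair, the chloro ortho to a trifluoromethyl group goes with the stronger effect. No evidence on hand accounts for this step.

Still open, going by these compounds, is how a fluoro or a methyl at this carbon would compare with chloro and hydrogen. On these data alone, the step's size with the hydroxy group of compound 1 in place of the methoxy group is also open.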